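Working notes: cytotoxicity across side-chain variants

The compounds below may be only part of what the source reports. "The series", "measured", "known", "first", "only" and "open" are said of these compounds alone.

Measured so far:
compound 1 `CC(C)CCn1nc(-c2cncs2)c(O)c(C2=NS(=O)(=O)c3cc(NS(C)(=O)=O)ccc3N2)c1=O` gives > 33000 nM in an ADME assay on Huh-7 cells (Homo sapiens) for cytotoxicity, with a stated time of 72 h; on this read-out higher numbers stand for lower toxicity in this test and lower numbers for higher toxicity in this test.
compound 2 `CCC(C)(C)Cn1nc(-c2cccs2)c(O)c(C2=NS(=O)(=O)c3cc(NS(C)(=O)=O)ccc3N2)c1=O` gives > 1000 nM in this assay.

Both values are limits of this assay rather than numbers. Compound 1 sits at the limit of > 33000 nM in this assay, at which 1 of the 2 values shown sits. Compound 2 sits at the limit of > 1000 nM in this assay, at which 1 of the 2 values shown sits, so its true half-maximal cytotoxic concentration is known only to lie beyond that point, and no comparison of size between the two compounds can be drawn from these readings; compound 2 stands simply as a compound without a measured toxicity figure in this assay.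

Compound 3 `CS(=O)(=O)Nc1ccc2c(c1)S(=O)(=O)N=C(c1c(O)c(-c3cccs3)nn(CCC3CCCC3)c1=O)N2` is the next analogue of compound 2. The change is cyclopentylmethyl in place of 1,1-dimethylpropyl on a saturated chain carbon bound to an aromatic nitrogen. Among the compounds with values here, no step between two measured compounds is available here, so the expectation rests on the change alone: with one saturated hydrocarbon group exchanged for another of similar size at the same place, no shift beyond the usual scatter in this assay is expected, and the step that the limit leaves unreadable from compound 2 to compound 3 is estimated as essentially flat. For compound 3 the half-maximal cytotoxic concentration in this assay is expected at about 30000 nM, within roughly 3000 nM to 100000 nM, most likely reported again only as a limit.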

Compound 3, half-maximal cytotoxic concentration: > 1000 nM
Compound 3 gave a limit, no number; the forecaster's own chance of this, stated with the estimate: 80%; the middle value lies beyond the limit too.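

No step can be read from compound 2 to compound 3, as both readings are limits and not numbers: the limit of > 1000 nM in this assay, at which 2 of the 3 values shown sit.

The compounds shown leave open whether cyclopentylmethyl and 1,1-dimethylpropyl differ at all in half-maximal cytotoxic concentration, and where the true values of compound 2 and compound 3 lie.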